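This account rests on a few compounds, and the source may have more. Where it says the series, first, only, none or still open, it means among the compounds named here.

The measured compounds and their numbers in an assay on CHO cells for displacement of a labelled ligand from adenosine receptor A3 (Homo sapiens), read by scintillation counting, tested at 10 uM; a lower number here means less inhibition, a higher number more inhibition at the concentration tested (going by the name of the read-out):

compound 1 `CC(C)(C)Cc1c(-c2ccoc2)sc(N)c1C(=O)c1ccc(Cl)cc1`: 1%
compound 2 `CC(C)(C)Cc1c(-c2ccccc2)sc(N)c1C(=O)c1ccc(Cl)c(Cl)c1`: 6%
compound 3 `COc1ccc(-c2sc(N)c(C(=O)c3cccc(C(F)(F)F)c3)c2CC(C)(C)C)cc1`: 1%

In this assay compound 1 gives 1%, level at the digits shown with compound 3, which gives 1%; together these two are the lowest of the measured numbers. Among the compounds with values here, the number for compound 2, 6%, differs from that of compound 1 by an amount that lies within the usual scatter of this kind of measurement, so none of the measured compounds can be told apart from the others on these numbers. All of them show little displacement of the labelled ligand.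

Compound 4 `Cc1noc(C)c1-c1sc(N)c(C(=O)c2ccc(Cl)cc2)c1CC(C)(C)C` has not been measured. It is built on the shared core, and it differs from compound 1 in one place: 3,5-dimethyl-1,2-oxazol-4-yl in place of furan-3-yl on an aromatic carbon. Among the measured compounds the group at this place already varies, and the read-out stays low throughout, with compound 2 and compound 3 lying together with compound 1. A step of a number 2 percentage points higher from compound 1 to compound 4 (within the scatter) is therefore expected, none beyond the scatter. For compound 4 in this assay a value of 3% is estimated, expected to fall between -8% and 15%.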

Compound 4, a percentage reported as inhibition, at one concentration (the size of the read-out at that concentration, not a potency): 1%
Estimate against measurement, compound 4: 2 percentage points above; the range from low to high includes it.
By their numbers in this assay, from the lowest: compounds 1, 3, 4 and 2 (each within the scatter of the next).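

In this assay, 3,5-dimethyl-1,2-oxazol-4-yl in place of furan-3-yl gives no change at the digits printed from compound 1 to compound 4 (within the scatter) and is the first step shown in which only this group changes, as the earlier compounds differed in more than one place. It shows directly that, on the core of compound 1, this larger group, with its second ring hetero atom and extra hydrogen-bond acceptor, leaves the read-out as low as furan-3-yl does. No measurement at hand accounts for this result.

All the groups shown at this position are aromatic rings, so how an amine, a carboxylic acid or a longer alkyl chain on this carbon would read remains open. Also open, from the compounds shown here alone, is whether a methyl group in place of the neopentyl group would change the read-out on this core.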